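A Stereocentre Left Undrawn on a Long Chain

A few compounds are considered here, and "the series" means these few. Any claim that something is new, unique, unknown or untested is made for them only; others in the source may bear on it.

In a functional assay on HCT-116 cells (Homo sapiens) for antiproliferative activity, read by MTT assay, with a stated time of 48 h (on this read-out higher numbers stand for weaker inhibition and lower numbers for stronger inhibition), compound 1 `CCCCCCCC(CCO)n1cnc2c(Cl)ncnc21` gives 4160 nM. Compound 2 `CCCCCCCCC[C@H](CCO)n1cnc2c(Cl)ncnc21` gives 450 nM, the lower of the two numbers, and the gap between them lies beyond the usual scatter. Compound 3 `CCCCCCCCCC(CCO)n1cnc2c(Cl)ncnc21` has the same atoms and bonds as compound 2: the two compounds have the same atoms and bonds; at least one stereo element is drawn with a configuration in one of them and without one in the other: 1 of 1 stereo elements differ; a stereocentre at a saturated chain carbon is drawn R in compound 2 and without a configuration in compound 3. The stereocentre at a saturated chain carbon, drawn R in compound 2, is drawn without a configuration in compound 3. In this assay, no change beyond the scatter is expected, with only a slight drift towards a higher number. The expected size is a 1.3-fold higher number from compound 2 to compound 3 (0.11 log units; within the scatter). For compound 3, the estimated value is 580 nM, within an expected range of 280 nM to 1200 nM.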

Compound 3, half-maximal inhibitory concentration: 890 nM
For compound 3 the middle estimate is 1.5-fold (0.19 log units) below the measured one; the range from low to high includes it.
By their numbers in this assay, from the lowest: compounds 2 and 3 (each within the scatter of the next); then compound 1.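

In this assay, among the compounds shown here, the stereocentre on the chain can now be read for the first time: a 2.0-fold higher number from compound 2 to compound 3 (0.30 log units; within the scatter). The chain length can also be read as a single change, ethyl in place of hydrogen on a saturated chain carbon, with a 4.7-fold lower number from compound 1 to compound 3 (0.67 log units; beyond the scatter). What compound 2 and compound 3 can say about configuration is limited: the fact that one of compounds 2 and 3 is drawn with a defined configuration and the other without, at the place where they differ

Going by these compounds, how the S configuration at this carbon would read remains open. So does whether a longer chain, or a carboxylic acid in place of the terminal hydroxyl, would keep this activity.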